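A few compounds are considered here, and "the series" means these few. Any claim that something is new, unique, unknown or untested is made for them only; others in the source may bear on it.

Measured so far in a functional assay (aorta) with Rattus norvegicus as the target; a lower number here means that less compound is needed, a higher number that more compound is needed for the effect:

compound 1, `N#Cc1ccc2c(c1)[C@@H](N1CCCC1=O)[C@H](O)C(CF)(CF)O2`, gives 85.1 nM
compound 2, `O=C1CCCN1[C@@H]1c2cc([N+](=O)[O-])ccc2OC(CF)(CF)[C@H]1O`, gives 24 nM
compound 3, `N#Cc1ccc2c(c1)[C@@H](n1ccccc1=O)[C@H](O)C(CF)(CF)O2`, gives 148 nM

Two changes run through this small set. Among the measured compounds shown here, the first is the exchange of the ring on the saturated carbon: compound 1 and compound 3 differ by a group of 7 heavy atoms (5 carbon, 1 nitrogen, 1 oxygen; one six-membered aromatic ring with 1 hetero atom) in place of a group of 6 heavy atoms (4 carbon, 1 nitrogen, 1 oxygen; one five-membered non-aromatic ring with 1 hetero atom), on a saturated ring carbon, and the step is a 1.7-fold higher number from compound 1 to compound 3 (0.24 log units; within the scatter), so the two cores cannot be told apart on this read-out.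

The second is the exchange of the group on the aromatic carbon: compound 1 and compound 2 differ by nitro in place of cyano on an aromatic carbon, and this step is a 3.5-fold lower number from compound 1 to compound 2 (0.55 log units; beyond the scatter). For the measured compounds named here, it is the only one of the two changes that moves the number beyond the scatter.

Compound 4, `O=c1ccccn1[C@@H]1c2cc([N+](=O)[O-])ccc2OC(CF)(CF)[C@H]1O`, has not been measured in this assay. It differs from compound 3 by nitro in place of cyano on an aromatic carbon, which is the same change as that from compound 1 to compound 2, on the same kind of position of the same ring system; only the core, as described above, is different.

Going by the values given here, for compound 4 in this assay the expected step is a 3.3-fold lower number from compound 3 to compound 4 (0.52 log units; beyond the scatter), resting on the single earlier instance of this change, a 3.5-fold lower number from compound 1 to compound 2 (0.55 log units; beyond the scatter), and on the two cores showing no separable difference in a 1.7-fold higher number from compound 1 to compound 3 (0.24 log units; within the scatter). Since that earlier step rests on one pair only, the range is kept wide. Compound 4 is estimated at 45 nM, with a plausible span from 18 nM to 110 nM.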

Compound 4, half-maximal effective concentration: 28.8 nM
Estimate against measurement, compound 4: 1.6-fold (0.19 log units) above; the range from low to high includes it.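

In this assay, nitro in place of cyano on the aromatic carbon gives a 5.1-fold lower number from compound 3 to compound 4 (0.71 log units; beyond the scatter), and this step carries over between the two cores with no separable difference in size: the same change on two cores in this assay, a 3.5-fold lower number (0.55 log units; beyond the scatter) from compound 1 to compound 2 and a 5.1-fold lower number (0.71 log units; beyond the scatter) from compound 3 to compound 4, 1.4-fold (0.16 log units) apart, within the scatter of two such steps

The exchange of the ring on the saturated carbon, read with nitro in place, gives a 1.2-fold higher number from compound 2 to compound 4 (0.08 log units; within the scatter), so compound 2 and compound 4 cannot be told apart here, and this step agrees with the one read with cyano in place: the same change on two cores in this assay, a 1.7-fold higher number (0.24 log units; within the scatter) from compound 1 to compound 3 and a 1.2-fold higher number (0.08 log units; within the scatter) from compound 2 to compound 4, 1.4-fold (0.16 log units) apart, within the scatter of two such steps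

Within these four compounds the two changes therefore appear to act independently, but this rests on only two cores, one pair of aromatic groups and a single read-out, and it does not show that the nitro step would hold on any other core or what lies behind it.

On these data alone, whether the step extends to other groups on that aromatic carbon, such as an amine or a carboxylic acid, remains open. As far as these compounds go, it is equally open whether another ring on the saturated carbon, or an open-chain amide in its place, would leave the number as unchanged as the exchange between these two rings does.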